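The source may hold more compounds than are shown below. What is called first, only, known or untested is meant among the compounds shown, and "the series" means these compounds.

For the measured compounds named here, compound 2 `O=c1c(Cc2coc3cccc(O)c3c2=O)coc2ccccc12` holds the only numbered value in a functional assay on NCI-H23 cells (Homo sapiens) for antiproliferative activity, read by XTT assay; on this read-out higher numbers stand for weaker inhibition and lower numbers for stronger inhibition; in that assay compound 2 gives 7550 nM. Compound 1 `CC(C)CCOc1cccc2occ(Cc3coc4ccccc4c3=O)c(=O)c12` reports only a limit in this assay, > 10000 nM. Going by the values given here, the single measured step, an at least 1.3-fold lower number from compound 1 to compound 2 (0.12 log units; that floor lies within the scatter), thus carries a floor only, and the floor sits within the scatter, as does the reading at the limit of > 10000 nM in this assay, at which 1 of the 2 values shown sits. Compound 3 `O=c1c(Cc2coc3cccc(OCc4ccccc4)c3c2=O)coc2ccccc12` carries benzyl in place of hydrogen on an oxygen on an aromatic ring. The change runs opposite to the measured step, with a larger group entering, so the expected step of a 1.3-fold higher number from compound 2 to compound 3 (0.10 log units; within the scatter) points toward a weaker number, if any. Compound 3 is expected near 9500 nM, between 4000 nM and 22000 nM.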

Compound 3, half-maximal inhibitory concentration: > 10000 nM
Compound 3: no number, only a limit; the forecaster's own chance of this, stated with the estimate: 40%; at least 1.0-fold (0.02 log units) between middle value and limit.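

Going from hydroxy to benzyloxy on this oxygen gives an at least 1.3-fold higher number from compound 2 to compound 3 (0.12 log units; that floor lies within the scatter), again a floor only. In this assay, an ether bearing a six-membered aromatic ring thus ends at a limit, as the isopentyl ether does, so neither ether gives a number: the limit of > 10000 nM in this assay, at which 2 of the 3 values shown sit. The step between compound 1 and compound 3 cannot be read, as both values are limits.

On these data alone, how far either ether lies past that limit stays open. So does whether a small methyl ether or an aminoethyl ether on this oxygen would give a number near that of compound 2.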